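The source may report more compounds than this note shows. Statements on the series, on what has been measured and on what is new or still open speak of the compounds shown alone.

In an ADME assay on SH-SY5Y cells (Homo sapiens) for cytotoxicity, read by MTT assay, with a stated time of 72 h (on this read-out higher numbers stand for weaker inhibition and lower numbers for stronger inhibition), compound 1 `O=C(CN1CCN(C(=O)c2ccc(F)cc2)CC1)N1CCN(CCCc2c[nH]c3ccccc23)CC1` gives 188000 nM, compound 2 `O=C(CN1CCN(C(=O)c2ccccc2)CC1)N1CCN(CCCc2c[nH]c3ccc(F)cc23)CC1` gives 146000 nM and compound 3 `O=C(CN1CCN(C(=O)c2ccc(F)cc2)CC1)N1CCN(CCCc2c[nH]c3ccc(F)cc23)CC1` gives 121000 nM. These three numbers lie within the usual scatter of one another, so compound 3 cannot be told apart from the other two. Compound 4 `O=C(CN1CCN(C(=O)c2ccccc2Br)CC1)N1CCN(CCCc2c[nH]c3ccc(F)cc23)CC1` differs from compound 3 by one change (2-bromophenyl in place of 4-fluorophenyl on a carbonyl carbon), with 2-bromophenyl in place of 4-fluorophenyl on a carbonyl carbon. The nearest measured steps both put fluoro in place of hydrogen on an aromatic carbon: a 1.6-fold lower number from compound 1 to compound 3 (0.19 log units; within the scatter) and a 1.2-fold lower number from compound 2 to compound 3 (0.08 log units; within the scatter). Going by the values given here, both are small, but no measured compound carries bromine, so the guide is only partial. In this assay, no change beyond the scatter is expected, and the estimated step is a 1.0-fold lower number from compound 3 to compound 4 (0.00 log units; within the scatter). Compound 4 is expected at 120000 nM, with an estimated range of 65000 nM to 220000 nM.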

Compound 4, half-maximal inhibitory concentration: 79100 nM
Estimate against measurement, compound 4: 1.5-fold (0.18 log units) above; measured number inside the range.
By their numbers in this assay, from the lowest: compounds 4, 3, 2 and 1 (each within the scatter of the next, the first and the last beyond it).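

In this assay, the 2-bromophenyl group brings the first bromine to this carbonyl carbon, and replacing 4-fluorophenyl with it gives a 1.5-fold lower number from compound 3 to compound 4 (0.18 log units; within the scatter) on this read-out. Starting instead from the phenyl ring that carries no halogen, the bromine gives a 1.8-fold lower number from compound 2 to compound 4 (0.27 log units; within the scatter) here. Both steps stay within the scatter, so bromine at this place, like fluorine, produces no change that can be told apart.

No measurement shown gives a reason for these numbers. An amine or a carboxylic acid on this phenyl ring remains an open case.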